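A few compounds are considered here, and "the series" means these few. Any claim that something is new, unique, unknown or untested is made for them only; others in the source may bear on it.

Working notes on the series. In a functional assay on CHO-K1 cells for antagonist activity at transient receptor potential cation channel subfamily V member 1 (Homo sapiens), read by FLIPR (on this read-out lower numbers stand for stronger inhibition and higher numbers for weaker inhibition), compound 1 `CCCCNc1nc(C(F)(F)F)ccc1CNC(=O)C(C)c1ccc(NS(C)(=O)=O)c(F)c1` gives 293 nM, compound 2 `CC(C(=O)NCc1ccc(C(F)(F)F)nc1N(C)c1ccccc1)c1ccc(NS(C)(=O)=O)c(F)c1` gives 57.4 nM, and compound 3 `CC(C(=O)NCc1ccc(C(F)(F)F)nc1N1CCC(Cc2cc(F)cc(F)c2)CC1)c1ccc(NS(C)(=O)=O)c(F)c1` gives 24 nM, the lowest of the three numbers, with compound 2 nearest and compound 1 furthest. For the measured compounds named here, the only single-point step measured so far is a 5.1-fold lower number from compound 1 to compound 2 (0.71 log units; beyond the scatter). Compound 4 `COC1CCN(c2nc(C(F)(F)F)ccc2CNC(=O)C(C)c2ccc(NS(C)(=O)=O)c(F)c2)CC1` differs from compound 3 by methoxy in place of 3,5-difluorobenzyl on a saturated ring carbon. Going by the values given here, no measured step covers this change; the nearest guide is that compound 1, which carries no aromatic ring on the amino group, gives 293 nM while compound 3 gives 24 nM. A loss of potency is therefore expected, estimated as a 4.6-fold higher number from compound 3 to compound 4 (0.66 log units; beyond the scatter) in this assay. For compound 4 the expected value is 110 nM, with a range of 30 nM to 400 nM.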

Compound 4, half-maximal inhibitory concentration: 280 nM
Compound 4: middle estimate off by 2.5-fold (0.41 log units), on the low side; the measured number falls inside the stated range.
By their numbers in this assay, from the lowest: compound 3; then compound 2; then compounds 4 and 1 (each within the scatter of the next).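

Methoxy in place of 3,5-difluorobenzyl on this saturated ring carbon is a large loss (a 12-fold higher number from compound 3 to compound 4 (1.07 log units; beyond the scatter)), so this place is sensitive to the change. With 4-methoxypiperidin-1-yl on the aromatic carbon, the comparison with methyl(phenyl)amino also shows a loss (a 4.9-fold higher number from compound 2 to compound 4 (0.69 log units; beyond the scatter)), while the comparison with butylamino stays within the scatter (a 1.0-fold lower number from compound 1 to compound 4 (0.02 log units; within the scatter)). No measurement bears on the reason for these steps. Still open, from the compounds shown here alone, is whether an unsubstituted benzyl or a phenoxy group on the same ring carbon would hold the potency of compound 3.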